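Two chlorines in place of one fluorine on the benzyl ring

The source may report more compounds than this note shows. Statements on the series, on what has been measured and on what is new or still open speak of the compounds shown alone.

Measured in a functional assay on Jurkat cells (Homo sapiens); a higher number here means a weaker inhibitor, a lower number a stronger inhibitor:
- compound 1 `C[C@H](NC(=O)C(=O)NCc1ccc(Cl)cc1)C(=O)N[C@@H](CC(=O)O)C(=O)COc1c(F)c(F)cc(F)c1F`: 8.4 nM
- compound 2 `Cc1ccccc1CNC(=O)C(=O)N[C@@H](C)C(=O)N[C@@H](CC(=O)O)C(=O)COc1c(F)c(F)cc(F)c1F`: 52 nM
- compound 3 `C[C@H](NC(=O)C(=O)NCc1ccc(F)cc1)C(=O)N[C@@H](CC(=O)O)C(=O)COc1c(F)c(F)cc(F)c1F`: 197 nM

Compound 3 has the highest of the three numbers, and so is the weakest inhibitor among them. Its nearest neighbour is compound 2, with a 3.8-fold higher number from compound 2 to compound 3 (0.58 log units; beyond the scatter); the step to compound 1 is larger, a 23-fold higher number from compound 1 to compound 3 (1.37 log units; beyond the scatter).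

Compound 4 `C[C@H](NC(=O)C(=O)NCc1cc(Cl)cc(Cl)c1)C(=O)N[C@@H](CC(=O)O)C(=O)COc1c(F)c(F)cc(F)c1F` differs from compound 3 as follows: 3,5-dichlorophenyl in place of 4-fluorophenyl on a saturated chain carbon bound to an amide-type nitrogen. Going by the values given here, the only measured step that bears on this change is the one between compound 1 and compound 3, where a chloro on the aromatic carbon was replaced by a fluoro and the number rose sharply, a 23-fold higher number from compound 1 to compound 3 (1.37 log units; beyond the scatter). Compound 4 reverses that direction, returning to chlorine, though now as two chlorines in a different arrangement, for which nothing has been measured. A drop in the number is therefore expected for compound 4, probably a large one, but with wide uncertainty, estimated as a 7.9-fold lower number from compound 3 to compound 4 (0.90 log units; beyond the scatter). Compound 4 is expected to give 25 nM in this assay, within a range from 6 nM to 110 nM.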

Compound 4, half-maximal inhibitory concentration: 23 nM
The estimate for compound 4 lay 1.1-fold (0.04 log units) above the measured number; the range from low to high includes it.
By their numbers in this assay, from the lowest: compound 1; then compound 4; then compound 2; then compound 3.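

In this assay, the move from 4-fluorophenyl to 3,5-dichlorophenyl lowers the number substantially (an 8.6-fold lower number from compound 3 to compound 4 (0.93 log units; beyond the scatter)), so the advantage of chlorine-bearing rings over compound 3 at this position is not confined to the single arrangement in 4-chlorophenyl. More chlorine does not simply mean a lower number, however: 3,5-dichlorophenyl improves on 2-methylphenyl (a 2.3-fold lower number from compound 2 to compound 4 (0.35 log units; beyond the scatter)) but falls short of 4-chlorophenyl with its one chlorine (a 2.7-fold higher number from compound 1 to compound 4 (0.44 log units; beyond the scatter)), leaving compound 4 in the middle of the series. Nothing available here explains why the four benzyl rings fall in this order.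

Compound 1 and compound 4 differ in both the number of chlorines and where they sit, so these compounds cannot show which of the two accounts for the step between them. Going by these compounds, it also remains open where a ring carrying bromine, a methoxy group or a trifluoromethyl group would fall in this order, and whether any such ring could match 4-chlorophenyl.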